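This account rests on a few compounds, and the source may have more. Where it says the series, first, only, none or still open, it means among the compounds named here.

Measured so far in this series:
compound 1 `O=C1CN(S(=O)(=O)c2cc3ccc(Cl)cc3s2)CCN1Cc1cc2c[nH]ccc-2n1`: > 2900 nM
compound 2 `O=C1CN(S(=O)(=O)c2cc3ccc(Cl)cc3s2)CCN1Cc1nc2cc[nH]cc-2n1`: > 2900 nM

In an assay on isolated protein for binding affinity to serine protease 1 (Homo sapiens) (on this read-out lower numbers stand for stronger inhibition and higher numbers for weaker inhibition), compound 1 gives only a limit, > 2900 nM. Compound 2 likewise reaches only the limit of this assay, > 2900 nM. The step that the two limits leave unreadable from compound 1 to compound 2 is thus not readable in size or direction. Compound 3 `O=C1CN(S(=O)(=O)c2cc3ccc(Cl)cc3s2)CCN1Cc1cc2c(O)[nH]ccc-2n1` differs from compound 2 by a group of 10 heavy atoms (7 carbon, 2 nitrogen, 1 oxygen; one five-membered aromatic ring with 1 hetero atom, one six-membered aromatic ring with 1 hetero atom) in place of a group of 9 heavy atoms (6 carbon, 3 nitrogen; one five-membered aromatic ring with 2 hetero atoms, one six-membered aromatic ring with 1 hetero atom), on a saturated chain carbon bound to an amide-type nitrogen in a ring. Going by the values given here, no measured step bears on this change; the only evidence is the limit of > 2900 nM in this assay, at which 2 of the 2 values shown sit. Compound 3 is expected to sit near 4000 nM, estimated between 1500 nM and 12000 nM, meaning an expected step that the limit leaves unreadable from compound 2 to compound 3 in this assay, with a fair chance that only a limit is reported again.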

Compound 3, inhibition constant: > 2900 nM
Compound 3: only a limit was reported (the forecaster's own chance of this, stated with the estimate: 65%); the middle value does not contradict the limit.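

Compound 3 gives only a limit in this assay, > 2900 nM, so its steps from compound 1 and compound 2 cannot be read. The compounds shown leave open whether hydroxy in place of hydrogen on an aromatic carbon changes inhibition at all.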